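This account rests on a few compounds, and the source may have more. Where it says the series, first, only, none or still open, it means among the compounds named here.

Measured compounds:

compound 1, `CC(=O)N[C@H]1[C@@H](OC[C@@H](O)[C@@H](O)[C@H](O)[C@@H](O)CNc2cccc(NC(=O)CCCCC3CCSS3)c2)O[C@H](CO)[C@H](O)[C@@H]1O[C@@H]1O[C@H](C(=O)O)[C@@H](O)[C@H](OS(=O)(=O)O)[C@H]1O`, 25 nM

compound 2, `CC(=O)N[C@H]1[C@@H](OC[C@@H](O)[C@@H](O)[C@H](O)[C@@H](O)CNc2cccc(NC(=O)CCCCC3CCSS3)c2)O[C@H](COS(=O)(=O)O)[C@H](O)[C@@H]1O[C@@H]1O[C@H](C(=O)O)[C@@H](O)[C@H](O)[C@H]1OS(=O)(=O)O`, 23 nM

compound 3, `CC(=O)N[C@H]1[C@@H](OC[C@@H](O)[C@@H](O)[C@H](O)[C@@H](O)CNc2cccc(NC(=O)CCCCC3CCSS3)c2)O[C@H](CO)[C@H](O)[C@@H]1O[C@@H]1O[C@H](C(=O)O)[C@@H](O)[C@H](OS(=O)(=O)O)[C@H]1OS(=O)(=O)O`, 95 nM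

All three were tested in an assay on isolated protein for binding affinity to fibroblast growth factor 2 (Homo sapiens), read by surface plasmon resonance; a higher number here means weaker binding, a lower number tighter binding. Compound 1 and compound 2 give numbers that lie within the usual scatter of each other, so no order between them can be read from these two values. The difference between the cores of compound 1 and compound 2 is not broken down here.

Compound 3 is made from compound 1 by one change: sulfo in place of hydrogen on an oxygen on a saturated carbon. This change gave a 3.8-fold higher number from compound 1 to compound 3 (0.58 log units; beyond the scatter), so the sulfated compound binds less tightly than its parent.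

Compound 4, `CC(=O)N[C@H]1[C@@H](OC[C@@H](O)[C@@H](O)[C@H](O)[C@@H](O)CNc2cccc(NC(=O)CCCCC3CCSS3)c2)O[C@H](COS(=O)(=O)O)[C@H](OS(=O)(=O)O)[C@@H]1O[C@@H]1O[C@H](C(=O)O)[C@@H](O)[C@H](O)[C@H]1OS(=O)(=O)O`, has not yet been measured. It stands to compound 2 as compound 3 stands to compound 1: sulfo in place of hydrogen on an oxygen on a saturated carbon. The place of the change reads the same in both pairs, so it is the same change on two different cores. Among the compounds with values here, only one measured example of this change exists, and its size is modest, so the expectation for compound 4 rests on a single step and carries real uncertainty.

For compound 4 the expected step is a 3.0-fold higher number from compound 2 to compound 4 (0.48 log units; beyond the scatter), because the same change in compound 1 gave a 3.8-fold higher number from compound 1 to compound 3 (0.58 log units; beyond the scatter), and compound 2 starts from a number close to that of compound 1. The estimated value for compound 4 in this assay is therefore 70 nM, with a likely range from 30 nM to 170 nM.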

Compound 4, dissociation constant: 21 nM
Beside the measured number, compound 4's estimate is 3.3-fold (0.52 log units) above it, outside the stated range (below it).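

In this assay, placing the sulfo group on compound 2 gave a 1.1-fold lower number from compound 2 to compound 4 (0.04 log units; within the scatter), so on this core the change has no readable effect on binding, and the tighter or weaker order of the pair cannot be told. Within the data shown here, a step measured on one core therefore cannot simply be carried over to the other, since the same change gave clearly different results on the two cores: the same change on two cores in this assay, a 3.8-fold higher number (0.58 log units; beyond the scatter) from compound 1 to compound 3 and a 1.1-fold lower number (0.04 log units; within the scatter) from compound 2 to compound 4, 4.2-fold (0.62 log units) apart, beyond the scatter of two such steps This shows that the outcome of adding the sulfo group depends on the core it is added to, but with only two pairs it does not show which feature of the cores is responsible, nor which of the two results a further core would follow.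

The compounds shown leave open what a phosphate or a methyl ether would do in place of the sulfo group on the same oxygen, on either core. They also leave open whether a third core would lose binding with this change, as the core of compound 1 does, or keep it, as the core of compound 2 does.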